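Sigma-1 binding: indolylmethyl to cyclopropylmethyl on the ring amine

This account rests on a few compounds, and the source may have more. Where it says the series, first, only, none or still open, it means among the compounds named here.

The series shares a core of two fluorophenyl rings on a carbon bearing a sulfur-linked chain to a secondary amine on a piperidine; the groups on the ring amine nitrogen differ. In an assay on membranes from Cortex for displacement of a labelled ligand from Sigma non-opioid intracellular receptor 1 (Cavia porcellus), read by scintillation counting, with a stated time of 120 min (a lower number here means a stronger inhibitor, a higher number a weaker inhibitor), compound 1 `O=C(c1cc2ccccc2o1)N1CCC(NCCSC(c2ccc(F)cc2)c2ccc(F)cc2)CC1` gives 304 nM and compound 2 `Fc1ccc(C(SCCNC2CCN(Cc3cc4ccccc4[nH]3)CC2)c2ccc(F)cc2)cc1` gives 205 nM. The step of a 1.5-fold lower number from compound 1 to compound 2 (0.17 log units; within the scatter) stays within the scatter, so compound 2 is indistinguishable from compound 1 on these two numbers.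

Compound 3 `Fc1ccc(C(SCCNC2CCN(CC3CC3)CC2)c2ccc(F)cc2)cc1` carries the change (cyclopropyl in place of 1H-indol-2-yl on a saturated chain carbon bound to an amine nitrogen in a ring). For the measured compounds named here, the only measured step that bears on the ring amine nitrogen is the swap from compound 1 to compound 2, which exchanged one bicyclic aromatic group for another and left the number essentially unchanged. Going by the values given here, no measured compound has a small saturated group on that nitrogen, so the step has no direct precedent in the data; it is therefore expected that compound 3 gives a somewhat higher number than compound 2, a step of a 2.4-fold higher number from compound 2 to compound 3 (0.39 log units; beyond the scatter), with wide uncertainty. The estimate for compound 3 in this assay is 500 nM, within the range 150 nM to 2000 nM.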

Compound 3, inhibition constant: 269 nM
Compound 3: middle estimate off by 1.9-fold (0.27 log units), on the high side, within the range that was stated.
By their numbers in this assay, from the lowest: compounds 2, 3 and 1 (each within the scatter of the next).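

In this assay, cyclopropyl in place of 1H-indol-2-yl on a saturated chain carbon bound to an amine nitrogen in a ring gives a 1.3-fold higher number from compound 2 to compound 3 (0.12 log units; within the scatter), even though the group goes from 9 heavy atoms to 3, gives up both aromatic rings and loses its hydrogen-bond donor. Cyclopropylmethyl in place of (1-benzofuran-2-yl)carbonyl on the amine nitrogen in the ring gives a 1.1-fold lower number from compound 1 to compound 3 (0.05 log units; within the scatter), so across these three compounds neither an aromatic group nor a carbonyl on that nitrogen separates one number from another, something the earlier pair, both carrying bicyclic aromatic groups, could not show. No measurement at hand accounts for why the numbers stay together across such different groups.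

Still open, on these data alone, is whether this flat response extends to a bare ring amine with only a hydrogen on the nitrogen, to a plain methyl, or to a longer chain such as n-butyl. Also open, as far as these compounds go, is whether a carboxylic acid at the end of such a chain on that nitrogen would stay within the same narrow band of numbers.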